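The source may report more compounds than this note shows. Statements on the series, on what has been measured and on what is new or still open speak of the compounds shown alone.

Measured compounds:
Compound 1 `Cc1cc(CN2C(=O)C(C3=NS(=O)(=O)c4cc(NS(C)(=O)=O)ccc4N3)=C(O)[C@H]3CCC[C@H]32)ccc1F` — > 1000 nM in an ADME assay on Huh-7 cells (Homo sapiens) for cytotoxicity, with a stated time of 72 h; on this read-out higher numbers stand for lower toxicity in this test and lower numbers for higher toxicity in this test
Compound 2 `CS(=O)(=O)Nc1ccc2c(c1)S(=O)(=O)N=C(C1=C(O)[C@H]3CCC[C@H]3N(Cc3ccc(F)c(Cl)c3)C1=O)N2` — > 1000 nM
Compound 3 `CS(=O)(=O)Nc1ccc2c(c1)S(=O)(=O)N=C(C1=C(O)[C@H]3CCC[C@H]3N(CC3CC3)C1=O)N2` — > 33000 nM

All three values in this assay are limits of the test rather than numbers. For compound 1 the value > 1000 nM is such a limit. For compound 2 the value > 1000 nM is likewise a limit. Among the compounds with values here, compound 3 stands at a different limit, > 33000 nM, which is the only information on it; the two other values shown are limits as well (the limit of > 1000 nM in this assay, at which 2 of the 3 values shown sit, (the limit of > 33000 nM in this assay, at which 1 of the 3 values shown sits)).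

Compound 4 `CC(C)CCN1C(=O)C(C2=NS(=O)(=O)c3cc(NS(C)(=O)=O)ccc3N2)=C(O)[C@H]2CCC[C@H]21` is not yet measured. It differs from compound 3 in one place: isobutyl in place of cyclopropyl on a saturated chain carbon bound to an amide-type nitrogen in a ring. The measured steps that change the same place are a step that the two limits leave unreadable from compound 1 to compound 3 and a step that the two limits leave unreadable from compound 2 to compound 3. Both are unreadable in size. Each runs between two limits. So no measured step gives a readable size for swapping one small carbon group for another at this position.

With only limits to go on, compound 3 is expected to be followed by a step that the limit leaves unreadable from compound 3 to compound 4 that stays within the scatter, and compound 4 is estimated at 40000 nM, between 10000 nM and 120000 nM, most likely reported again as a limit.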

Compound 4, half-maximal cytotoxic concentration: > 1000 nM
Compound 4: a limit, no number; the forecaster's own chance of this, stated with the estimate: 70%; the middle value lies beyond the limit too.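

In this assay compound 4 gives > 1000 nM, which is a limit of the test and not a number. Within the data shown here, compound 1, compound 2 and compound 3 also stand only at limits, so no step from any of them to compound 4 can be read. Still open, on these data alone, is whether changing the group on the saturated chain carbon bound to the ring's amide-type nitrogen alters the result in this assay at all.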